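Series notes: aryl-substituted pyrrolidine diols against fucosidase

A few compounds are considered here, and "the series" means these few. Any claim that something is new, unique, unknown or untested is made for them only; others in the source may bear on it.

Compound 1 `COc1cccc([C@]2(CO)NC[C@@H](O)[C@@H]2O)c1` carries a methoxy group on its aromatic ring. In an assay on isolated protein for inhibition of tissue alpha-L-fucosidase (Bos taurus), tested at 1000 uM (a lower number here means less inhibition, a higher number more inhibition at the concentration tested (going by the name of the read-out)), compound 1 gives 0%. Compound 2 `OC[C@@]1(c2cccc(F)c2)NC[C@@H](O)[C@@H]1O` replaces that methoxy with fluorine, and in this assay compound 2 gives 0%. Compound 3 `COc1cccc([C@@]2(CO)NC[C@H](O)[C@H]2O)c1` is the mirror image of compound 1 with all three stereocentres inverted; in this assay compound 3 gives 1.6%. On these three numbers compound 1 sits level with compound 2, the two together the lowest of the set, and compound 3 is nearest to them at the upper side, all within the scatter.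

The measured steps are small: no change at the digits printed from compound 1 to compound 2 (within the scatter) and a number 1.6 percentage points higher from compound 1 to compound 3 (within the scatter). That the second step stays flat even though the fact that compounds 1 and 3 differ only in the configuration as drawn shows that no configuration of the shared core has yet produced a measurable read-out.

Compound 4 `COc1ccc([C@]2(CO)NC[C@@H](O)[C@@H]2O)cc1OC` differs from compound 1 by methoxy in place of hydrogen on an aromatic carbon. Neither measured step bears directly on adding a second methoxy group, but both show changes at the aromatic ring or at the core leaving the read-out flat. The step expected in this assay is therefore a number 1 percentage points higher from compound 1 to compound 4 (within the scatter), no change beyond the scatter. For compound 4 the estimated value in this assay is 1%, in a range from 0% to 10%.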

Compound 4, a percentage reported as inhibition, at one concentration (the size of the read-out at that concentration, not a potency): 0%
Beside the measured number, compound 4's estimate is 1 percentage points above it; measured number inside the range.
By their numbers in this assay, from the lowest: compounds 1, 2, 4 and 3 (each within the scatter of the next).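

In this assay the entry of methoxy in place of hydrogen, on the aromatic carbon ortho to a methoxy group and para to a group of 9 heavy atoms, gives no change at the digits printed from compound 1 to compound 4 (within the scatter) and so leaves the read-out flat at this position. Unlike the step to compound 2, which exchanges one substituent for another, this change adds heavy atoms at a previously unsubstituted aromatic carbon, and that addition also produces no measurable movement at the concentration tested. Nothing in hand gives a reason for this flat step.

The compounds shown do not tell whether any substituent at this position can raise the read-out, since every number in the set lies within the scatter of the next. Going by these compounds, whether an amine or a carboxylic acid on this aromatic carbon, or a longer chain in place of the added methoxy, would move the read-out beyond the scatter stays open, as does whether the same added methoxy would behave alike on the mirror-image core of compound 3.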